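Chloro to methoxy on the longest chain

A few compounds are considered here, and "the series" means these few. Any claim that something is new, unique, unknown or untested is made for them only; others in the source may bear on it.

Measured in a functional assay on SW480 cells (Homo sapiens) for antiproliferative activity, read by MTT assay, with a stated time of 48 h; on this read-out higher numbers stand for weaker inhibition and lower numbers for stronger inhibition:
Compound 1 `CCCCCC(CCO)n1cnc2c(OC)ncnc21`: > 50000 nM (a limit of the assay, not a number)
Compound 2 `CCCCCCCC(CCO)n1cnc2c(OC)ncnc21`: 23900 nM
Compound 3 `CCCCCCCCCCC(CCO)n1cnc2c(Cl)ncnc21`: 3160 nM

Compound 3, at 3160 nM, holds the lowest number of the three, well under compound 2 at 23900 nM. The next compound, compound 4 `CCCCCCCCCCC(CCO)n1cnc2c(OC)ncnc21`, keeps the chain of compound 3 and changes one group on an aromatic carbon: methoxy in place of chloro on an aromatic carbon. In words, this is methoxy in place of chloro.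

Among the compounds with values here, no measured step makes this swap alone. Within the data shown here, the only step between measured neighbours is an at least 2.0-fold lower number from compound 1 to compound 2 (0.32 log units; beyond the scatter), which lengthens the chain among methoxy compounds, with ethyl in place of hydrogen. It bears on compound 4 only indirectly, since compound 4 carries methoxy on a longer chain than compound 2. Compound 2 differs from compound 3 in both chain and group, so the gap between those two cannot be divided between the changes.

Compound 4 is therefore expected to fall between compound 3 at 3160 nM and compound 2 at 23900 nM. The expected change is a 2.5-fold higher number from compound 3 to compound 4 (0.40 log units; beyond the scatter), toward weaker inhibition in this assay. For compound 4 the estimated value is 8000 nM, with an expected range from 2500 nM to 20000 nM.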

Compound 4, half-maximal inhibitory concentration: 8260 nM
Beside the measured number, compound 4's estimate is 1.0-fold (0.01 log units) below it; the range from low to high includes it.
By their numbers in this assay, from the lowest: compound 3; then compound 4; then compound 2. At a limit, above all of these: compound 1.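

In this assay, within the data shown here, a 2.6-fold higher number from compound 3 to compound 4 (0.42 log units; beyond the scatter), which gives the first reading of methoxy in place of chloro on an aromatic carbon with the chain held fixed. On this chain, chloro at this place gives the lower number, and the change moves toward weaker inhibition by a modest margin that lies beyond the scatter. Among the methoxy compounds, the order follows chain length without exception, with a 2.9-fold lower number from compound 2 to compound 4 (0.46 log units; beyond the scatter), and the series also gives an at least 6.0-fold lower number from compound 1 to compound 4 (0.78 log units; beyond the scatter), whose starting value is a limit of the assay and not a number: the limit of > 50000 nM in this assay, at which 1 of the 4 values shown sits.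

The swap has been read on one chain only, so the compounds shown leave open whether chloro would keep its lower number on shorter chains, and whether the chain-length trend seen with methoxy also holds with chloro. They also leave open how an amine or a fluoro group at this aromatic carbon would compare with chloro and methoxy, and whether a longer chain would lower the number further.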